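Nitro to amino: the expected step to compound 4

The compounds below may be only part of what the source reports. "The series", "measured", "known", "first", "only" and "open" are said of these compounds alone.

In a functional assay on K562 cells (Homo sapiens) for cytotoxicity, read by trypan blue exclusion, with a stated time of 96 h (on this read-out lower numbers stand for stronger inhibition and higher numbers for weaker inhibition), compound 1 `COc1ccc(NS(=O)(=O)/C=C/c2c(OC)cc(OC)cc2OC)cc1` gives 75 nM, compound 2 `COc1cc(OC)c(/C=C/S(=O)(=O)Nc2ccc(OC)c(O)c2)c(OC)c1` gives 15 nM and compound 3 `COc1cc(OC)c(/C=C/S(=O)(=O)Nc2ccc(OC)c([N+](=O)[O-])c2)c(OC)c1` gives 1000 nM, the highest of the three numbers. Compound 4 `COc1cc(OC)c(/C=C/S(=O)(=O)Nc2ccc(OC)c(N)c2)c(OC)c1` has amino in place of nitro on an aromatic carbon, ortho to a methoxy group: amino in place of nitro on an aromatic carbon. Within the data shown here, three measured steps bear on this change. Nitro gives a large 13-fold higher number from compound 1 to compound 3 (1.12 log units; beyond the scatter) and a large 67-fold higher number from compound 2 to compound 3 (1.82 log units; beyond the scatter), while hydroxy gives a modest 5.0-fold lower number from compound 1 to compound 2 (0.70 log units; beyond the scatter). With the nitro gone, a large step to a lower number is expected in this assay. The estimated step is a 25-fold lower number from compound 3 to compound 4 (1.40 log units; beyond the scatter). For compound 4 the expected value is 40 nM, with an estimated range of 10 nM to 200 nM.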

Compound 4, half-maximal inhibitory concentration: 3 nM
Compound 4: middle estimate off by 13-fold (1.12 log units), on the high side, outside the stated range (below it).
By their numbers in this assay, from the lowest: compound 4; then compound 2; then compound 1; then compound 3.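

In this assay, amino gives the lowest number of the four compounds, beating nitro (a 330-fold lower number from compound 3 to compound 4 (2.52 log units; beyond the scatter)), hydroxy (a 5.0-fold lower number from compound 2 to compound 4 (0.70 log units; beyond the scatter)) and hydrogen (a 25-fold lower number from compound 1 to compound 4 (1.40 log units; beyond the scatter)). At this place, ortho to a methoxy group, amino and hydroxy both lower the number relative to hydrogen, and only nitro raises it. Nothing measured here accounts for this order.

On these data alone, whether a methylamino or acetamido group at the same place keeps the low number remains open. So does whether amino keeps its lead in other cell lines.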